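The compounds below may be only part of what the source reports. "The series", "measured", "known", "first", "only" and "open" are said of these compounds alone.

In a functional assay on HCT-116 cells (Homo sapiens) for antiproliferative activity, read by MTT assay, with a stated time of 72 h (a lower number here means a stronger inhibitor, a higher number a weaker inhibitor), two compounds sharing one core have been measured so far. Compound 1 `C#Cc1cccc(NC(=O)CCc2cccc3c2B(O)OC3)c1`, which carries an ethynyl group, gives 3600 nM. Compound 2 `O=C(CCc1cccc2c1B(O)OC2)Nc1cccc(-c2cccc(Cl)c2)c1`, which carries a 3-chlorophenyl group in its place, gives 350 nM, the lower of the two numbers. The next compound is compound 3 `COc1cc(OC)cc(-c2cccc(NC(=O)CCc3cccc4c3B(O)OC4)c2)c1`, with 3,5-dimethoxyphenyl in place of 3-chlorophenyl on an aromatic carbon, meta to a large group: 3,5-dimethoxyphenyl in place of 3-chlorophenyl on an aromatic carbon. For the measured compounds named here, only one measured step bears on this change, and only indirectly. That step, a 10-fold lower number from compound 1 to compound 2 (1.01 log units; beyond the scatter), is large and lies beyond the scatter, but it exchanges ethynyl for 3-chlorophenyl. Going by the values given here, the new change instead swaps one substituted phenyl group for another, and no measured pair compares two such groups. Compound 3 keeps the aromatic ring that compound 2 carries at this place, so no large step is expected in this assay, and no direction can be argued from the data. The expected outcome is a 1.1-fold higher number from compound 2 to compound 3 (0.06 log units; within the scatter), which would stay within the scatter. For compound 3, the estimated value is 400 nM, with an expected range from 130 nM to 1200 nM.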

Compound 3, half-maximal inhibitory concentration: 53 nM
Beside the measured number, compound 3's estimate is 7.5-fold (0.88 log units) above it; measured number below the stated range.
By their numbers in this assay, from the lowest: compound 3; then compound 2; then compound 1.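

In this assay the exchange of one substituted phenyl group for another gives a 6.6-fold lower number from compound 2 to compound 3 (0.82 log units; beyond the scatter) at this aromatic carbon, so what the ring carries matters here and not only the presence of a ring. The earlier compounds shown here showed only that 3-chlorophenyl gives a lower number than ethynyl at this place, whereas 3,5-dimethoxyphenyl now extends the span to a 68-fold lower number from compound 1 to compound 3 (1.83 log units; beyond the scatter) in this assay and marks this position as one where changes on the outer ring still shift the read-out. No measurement given here accounts for the lower number seen with 3,5-dimethoxyphenyl.

The compounds shown leave open whether the methoxy groups are needed together, or whether a plain phenyl or a ring with a single methoxy group would give a similar number. They also leave open how a hydroxyl group, an amine or a carboxylic acid on this outer ring would compare with the methoxy groups, and whether the same ring keeps its effect when the chain to the shared core is longer.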